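This account rests on a few compounds, and the source may have more. Where it says the series, first, only, none or still open, it means among the compounds named here.

Working notes on the series.

Compound 1 `CC1=CC[C@H](C(C)(C)NC(=S)N/N=C/c2ccccc2)CC1` serves as the unsubstituted reference; in a functional assay on PC-3 cells (Homo sapiens) for inhibition, read by sulforhodamine B assay, with a stated time of 48 h (a lower number here means a stronger inhibitor of growth, a higher number a weaker inhibitor of growth), compound 1 gives 1300 nM. Compound 2 `COc1ccc(/C=N/NC(=S)NC(C)(C)[C@H]2CC=C(C)CC2)cc1` carries a methoxy in place of that hydrogen. In this assay compound 2 gives < 40 nM, which is a limit of the assay and not a number. Compound 3 `CC1=CC[C@H](C(C)(C)NC(=S)N/N=C/c2ccc(F)cc2)CC1` carries a fluoro instead. In this assay compound 3 gives < 40 nM, again a limit. So compound 3 stands at the floor of what was resolved, and the limit of < 40 nM in this assay, at which 2 of the 3 values shown sit, holds two of the three values. The steps of an at least 32-fold lower number from compound 1 to compound 2 (1.51 log units; beyond the scatter) and an at least 32-fold lower number from compound 1 to compound 3 (1.51 log units; beyond the scatter) are both large, while a step that the two limits leave unreadable from compound 2 to compound 3 cannot be read.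

Compound 4 `CC1=CC[C@H](C(C)(C)NC(=S)N/N=C/c2ccc[nH]2)CC1` differs from compound 3 by 1H-pyrrol-2-yl in place of 4-fluorophenyl on a carbon with a double bond to nitrogen. For the measured compounds named here, no measured step covers a swap of the whole aromatic ring; the measured steps only show that a substituent on the six-membered ring moves the number strongly. With that substituent gone and the ring changed, compound 4 is expected to move back towards compound 1, a step estimated as an at least 8.7-fold higher number from compound 3 to compound 4 (0.94 log units; beyond the scatter). For compound 4 the expected value is 350 nM, within 40 nM to 3000 nM.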

Compound 4, concentration for 50% growth inhibition: 2800 nM
Estimate against measurement, compound 4: 8.0-fold (0.90 log units) below, and the stated range covers the measured number.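

The place on a carbon with a double bond to nitrogen responds to a change of the whole aromatic ring, not only to a substituent on it: 1H-pyrrol-2-yl gives large steps against 4-fluorophenyl (an at least 70-fold higher number from compound 3 to compound 4 (1.84 log units; beyond the scatter)) and 4-methoxyphenyl (an at least 70-fold higher number from compound 2 to compound 4 (1.84 log units; beyond the scatter)). Against plain phenyl the step is modest, though beyond the scatter (a 2.2-fold higher number from compound 1 to compound 4 (0.33 log units; beyond the scatter)), so in this assay 1H-pyrrol-2-yl does not recover what the fluoro and methoxy substituents gain. The two large steps are open-ended because compound 2 and compound 3 rest on a limit: the limit of < 40 nM in this assay, at which 2 of the 4 values shown sit.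

From the compounds shown here alone, whether a fluoro or methoxy on the 1H-pyrrol-2-yl ring would act as it does on phenyl remains open. So does whether a furan-2-yl ring, or a methyl on the pyrrole nitrogen, would behave like 1H-pyrrol-2-yl.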